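Fluoro in place of methyl, from compound 3 to compound 4

A few compounds are considered here, and "the series" means these few. Any claim that something is new, unique, unknown or untested is made for them only; others in the source may bear on it.

In an ADME assay on microsomes from liver (Homo sapiens) for metabolic stability, with a stated time of 10 min (on this read-out lower numbers stand for a less stable compound and higher numbers for a more stable compound), compound 3 `Cc1cccc(C)c1COC(c1ccc([C@]2(S(=O)(=O)c3ccc(F)cc3)CCN(C(=O)[C@H]3CC[C@H](C(=O)O)CC3)C2)cc1)(C(F)(F)F)C(F)(F)F` gives 89%. That lies within the scatter of compound 2 `O=C(O)[C@H]1CC[C@H](C(=O)N2CC[C@](c3ccc(C(OCc4ccccc4OC(F)(F)F)(C(F)(F)F)C(F)(F)F)cc3)(S(=O)(=O)c3ccc(F)cc3)C2)CC1` at 93%. Compound 1 `CC(=O)N1CCN(C(=O)N2CC[C@](c3ccc(C(OCc4c(F)cccc4F)(C(F)(F)F)C(F)(F)F)cc3)(S(=O)(=O)c3ccc(F)cc3)C2)CC1` gives 5%. The gap between compound 3 and compound 1 lies far beyond the scatter. Compound 4 `Cc1cccc(F)c1COC(c1ccc([C@]2(S(=O)(=O)c3ccc(F)cc3)CCN(C(=O)[C@H]3CC[C@H](C(=O)O)CC3)C2)cc1)(C(F)(F)F)C(F)(F)F` differs from compound 3 by fluoro in place of methyl on an aromatic carbon, turning 2,6-dimethylbenzyl into 2-fluoro-6-methylbenzyl. Among the measured compounds shown here, one measured step bears on this change, the exchange of 2-(trifluoromethoxy)phenyl for 2,6-dimethylphenyl, a number 4 percentage points lower from compound 2 to compound 3 (within the scatter). As that step stayed within the scatter, no step beyond the scatter is expected in this assay here, and no direction can be favoured. The expected result is a number 2 percentage points lower from compound 3 to compound 4 (within the scatter). For compound 4 the estimated value is 87%, with an expected range from 72% to 97%.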

Compound 4, percent of the compound remaining: 79%
Compound 4: middle estimate off by 8 percentage points, on the high side; measured number inside the range.
By their numbers in this assay, from the lowest: compound 1; then compounds 4, 3 and 2 (each within the scatter of the next, the first and the last beyond it).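

In this assay, fluoro in place of methyl on an aromatic carbon gives a number 10 percentage points lower from compound 3 to compound 4 (within the scatter), so this exchange at the position stays inside the usual spread. Among the compounds shown here, the earlier benzyl change stayed within the scatter, whereas a number 14 percentage points lower from compound 2 to compound 4 (beyond the scatter) is the first modest step beyond it among the compounds with this shared core and acid side. No measured evidence accounts for this. Going by these compounds, whether a chloro or a methoxy group in place of this fluoro would stay within the scatter of compound 3 remains open. Compound 1 differs from the others in more than one place, so its value cannot be tied to the benzyl group.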